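A few compounds are considered here, and "the series" means these few. Any claim that something is new, unique, unknown or untested is made for them only; others in the source may bear on it.

Of the compounds shown here, three built on a shared core have been measured in an assay on isolated protein (strain albino) for antagonist activity at Voltage-dependent L-type calcium channel subunit alpha-1C (Cavia porcellus); on this read-out higher numbers stand for weaker inhibition and lower numbers for stronger inhibition. Compound 1 `COC(=O)C1=C(C)NC(C)=C(C(=O)OC(C)C)C1c1cnc(SC)n1Nc1ccccc1` gives 6.35 nM. Compound 2 `CCOC(=O)C1=C(C)NC(C)=C(C(=O)OC(C)C)C1c1cnc(SC)n1Nc1ccccc1` gives 3.22 nM, and compound 3 `CCOC(=O)C1=C(C)NC(C)=C(C(=O)OCCCc2ccccc2)C1c1cnc(SC)n1Nc1ccccc1` gives 2.54 nM. Compound 3 stands on the lowest of the three numbers; its gap to compound 2 lies within the scatter, while its gap to compound 1 lies beyond it. Two single changes connect these three: a 2.0-fold lower number from compound 1 to compound 2 (0.29 log units; within the scatter), and a 1.3-fold lower number from compound 2 to compound 3 (0.10 log units; within the scatter).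

Compound 4 `CSc1ncc(C2C(C(=O)OCCCc3ccccc3)=C(C)NC(C)=C2C(=O)OC(C)C)n1Nc1ccccc1` has not yet been measured. It differs from compound 3 by methyl in place of hydrogen on a saturated chain carbon bound to an oxygen next to a carbonyl group and a saturated chain carbon. The measured step that bears most directly on this is the one from methyl to ethyl on the same kind of carbon, a 2.0-fold lower number from compound 1 to compound 2 (0.29 log units; within the scatter), which stayed within the scatter. A further small lowering is therefore expected at most, and the expected step is a 1.3-fold lower number from compound 3 to compound 4 (0.10 log units; within the scatter), still within the scatter. Compound 4 is accordingly estimated at 2 nM, with a range from 0.8 nM to 5 nM.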

Compound 4, half-maximal inhibitory concentration: 6.22 nM
The estimate for compound 4 lay 3.1-fold (0.49 log units) below the measured number, and the stated range ends below it.
By their numbers in this assay, from the lowest: compounds 3, 2, 4 and 1 (each within the scatter of the next, the first and the last beyond it).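

Within the data shown here, the same methyl in place of hydrogen does not give the same step on every core in this assay, so its effect at this position depends on the rest of the molecule: the same change on two cores in this assay, a 2.0-fold lower number (0.29 log units; within the scatter) from compound 1 to compound 2 and a 2.4-fold higher number (0.39 log units; beyond the scatter) from compound 3 to compound 4, 4.8-fold (0.68 log units) apart, beyond the scatter of two such steps On the core of compound 3, which carries 3-phenylpropyl on its other ester, going from ethoxycarbonyl to isopropoxycarbonyl gives a 2.4-fold higher number from compound 3 to compound 4 (0.39 log units; beyond the scatter), the only single change so far to pass beyond the scatter. The other two routes to compound 4 stay within the scatter, with a 1.9-fold higher number from compound 2 to compound 4 (0.29 log units; within the scatter) and a 1.0-fold lower number from compound 1 to compound 4 (0.01 log units; within the scatter).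

Among these compounds, with only two cores compared, it remains open how this methyl would read on a third core. Also open, going by these compounds, is how a longer chain such as butyl, or a carboxylic acid, would read at this place.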